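The source may report more compounds than this note shows. Statements on the series, on what has been measured and on what is new or still open speak of the compounds shown alone.

Of the compounds shown here, two have so far been tested in a functional assay on the whole organism (strain Wistar Albino) for inhibition, with Rattus norvegicus as the target, read by paw edema, with a stated time of 2 h, at a dose of 20 mg/kg; on this read-out higher numbers stand for more inhibition at the one dose given (going by the name of the read-out) and lower numbers for less inhibition. Compound 1 `Cc1occc1-c1nnc2sc(-c3cc(O)nc(O)c3)nn12` gives 11.4%, and compound 2 `Cc1occc1-c1nnc2n1NC(c1ccco1)S2` gives 21.6%. Among the compounds with values here, on these two numbers compound 2 stands highest; its only neighbour, compound 1, lies lower by a gap that is beyond the usual scatter of such measurements. The next compound, compound 3 `Cc1occc1-c1nnc2n1NC(c1ccc([N+](=O)[O-])o1)S2`, has not yet been measured in this assay. It differs from compound 2 in one place: nitro in place of hydrogen on an aromatic carbon. Within the data shown here, no pair of measured compounds shows what such a change does here, so the expectation rests on compound 2 alone. In this assay the step is expected to be small, a number 3.4 percentage points higher from compound 2 to compound 3 (within the scatter), and may well not exceed the scatter in either direction. Compound 3 is therefore estimated at 25%, within a range from 10% to 40%.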

Compound 3, a percentage reported as inhibition, in the whole organism at one dose (the size of the read-out at that dose, not a potency): 18.1%
Compound 3: the middle estimate sits 6.9 percentage points above what was measured, and the stated range covers the measured number.
By their numbers in this assay, from the lowest: compounds 1, 3 and 2 (each within the scatter of the next, the first and the last beyond it).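

In this assay, nitro in place of hydrogen on an aromatic carbon of the five-membered aromatic ring with 1 oxygen, next to the ring oxygen, comes to a number 3.5 percentage points lower from compound 2 to compound 3 (within the scatter) at the one dose given. This first step between measured compounds that differ in one place shows that this position can carry a group of 3 heavy atoms with no change that stands clear of the scatter, so at this dose the read-out does not separate nitro from hydrogen here. Nothing measured on these compounds explains this result. From the compounds shown here alone, whether a different group at this position, such as an amine or a carboxylic acid, would move the read-out beyond the scatter remains open. Also open, going by these compounds, is whether nitro and hydrogen would stay this close at other doses or at other times.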